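The source may report more compounds than this note shows. Statements on the series, on what has been measured and on what is new or still open speak of the compounds shown alone.

Measured compounds:
- Compound 1 `CCCC(Oc1ccc(-n2cc(C(F)(F)F)cn2)c(C)c1)c1ccc(C(=O)NCCC(=O)O)cc1`: 200 nM
- Compound 2 `CCCC(Oc1ccc(-n2cc(Cl)cn2)cc1)c1ccc(C(=O)NCCC(=O)O)cc1`: 1100 nM

In an assay on cells for displacement of a labelled ligand from Glucagon receptor (Homo sapiens), in the presence of a further agent that is not named here (on this read-out lower numbers stand for stronger inhibition and higher numbers for weaker inhibition), compound 1 gives 200 nM. In this assay compound 2 gives 1100 nM, which is the higher of the two numbers, and the difference between these two compounds is beyond the scatter of repeated measurements.

Compound 3 `CCCC(Oc1ccc(-n2cccn2)cc1)c1ccc(C(=O)NCCC(=O)O)cc1` has not been measured in this assay. It departs from compound 2 in one place: hydrogen in place of chloro on an aromatic carbon. The chloro leaves the aromatic carbon of the five-membered aromatic ring with two nitrogens, and only a hydrogen takes its place.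

For the measured compounds named here, no step between measured compounds covers this change, so the direction can only be expected, not read off. Since compound 2 already has the higher number, and the substituent is simply removed, the expected step from compound 2 to compound 3, a 2.3-fold higher number from compound 2 to compound 3 (0.36 log units; beyond the scatter), is toward a further higher number, of a size that lies somewhat beyond the scatter but is not large. Compound 3 is therefore estimated to give 2500 nM in this assay, with a range from 1000 nM to 6500 nM.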

Compound 3, inhibition constant: 4100 nM
Compound 3: middle estimate off by 1.6-fold (0.21 log units), on the low side; the range from low to high includes it.
By their numbers in this assay, from the lowest: compound 1; then compound 2; then compound 3.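

In this assay, for the compounds shown here, the step of a 3.7-fold higher number from compound 2 to compound 3 (0.57 log units; beyond the scatter) is the first comparison here that isolates a single place: an aromatic carbon of the five-membered aromatic ring with 2 nitrogen, two ring bonds from the ring nitrogen. It shows that this carbon is not indifferent to what it carries, since the 4-chloro-1H-pyrazol-1-yl compound gives the lower number of the pair and the 1H-pyrazol-1-yl compound the higher, with a single chlorine atom as the whole difference. Nothing given here bears on why the removal of chloro has this effect.

On these data alone, it remains open whether this gain belongs to chloro in particular or would also come with another group on the same carbon, such as bromo, a nitrile or an amine on the otherwise unchanged core of compound 2. The trifluoromethyl group offers no answer, as compound 1 differs from compound 2 in a further place, so the share of that group in the lower number of compound 1 cannot be separated out.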